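The source may hold more compounds than are shown below. What is called first, only, known or untested is meant among the compounds shown, and "the series" means these compounds.

Measured so far:
compound 1 `N[C@]1(C(=O)O)[C@H]2[C@@H](C[C@H]1OCc1cc(F)cc(F)c1)[C@]2(F)C(=O)O`, in an assay on CHO cells for binding affinity to metabotropic glutamate receptor 2 (Rattus norvegicus) (on this read-out lower numbers stand for stronger inhibition and higher numbers for weaker inhibition), compound 1 gives 12.4 nM
compound 2 `N[C@]1(C(=O)O)[C@H]2[C@@H](C[C@H]1OCc1c(F)cccc1F)[C@]2(F)C(=O)O`, in this assay compound 2 gives 7.02 nM

Going by the values given here, compound 2 holds the lowest of the two numbers, and the only measured step, a 1.8-fold lower number from compound 1 to compound 2 (0.25 log units; within the scatter), lies within the scatter. Compound 3 `N[C@]1(C(=O)O)[C@H]2[C@@H](C[C@H]1OCc1ccc(F)c(Cl)c1)[C@]2(F)C(=O)O` differs from compound 2 by 3-chloro-4-fluorophenyl in place of 2,6-difluorophenyl on a saturated chain carbon bound to an oxygen on a saturated carbon. That step bears on it only as a change of the same aromatic ring, which so far moved the number little. Compound 3 is therefore expected to stay near compound 2, with the step of a 1.4-fold higher number from compound 2 to compound 3 (0.15 log units; within the scatter) and an estimate of 10 nM, in the range 3.5 nM to 30 nM.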

Compound 3, inhibition constant: 3.57 nM
Estimate against measurement, compound 3: 2.8-fold (0.45 log units) above, and the stated range covers the measured number.
By their numbers in this assay, from the lowest: compounds 3, 2 and 1 (each within the scatter of the next, the first and the last beyond it).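

In this assay, going by these compounds alone, the change to 3-chloro-4-fluorophenyl gives the first step at this position that lies beyond the scatter, a 3.5-fold lower number from compound 1 to compound 3 (0.54 log units; beyond the scatter), while a 2.0-fold lower number from compound 2 to compound 3 (0.29 log units; within the scatter) stays within it. The aromatic ring on this saturated chain carbon can therefore move the number modestly, and a ring carrying chlorine keeps it in the same range as compound 2. Nothing at hand gives a cause for this step.

From the compounds shown here alone, whether the chlorine or the placement of the fluorine carries the step remains open. So does how a ring bearing a methoxy group or a nitrile would read here.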